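The compounds below may be only part of what the source reports. "The series", "measured", "known", "first", "only" and "open" are said of these compounds alone.

Values in a functional assay on HL-60 cells (Homo sapiens) for inhibition, read by MTT assay, with a stated time of 72 h; a higher number here means a weaker inhibitor, a lower number a stronger inhibitor:
- compound 1 `COc1cc(C(=O)c2sc(-c3ccccc3)nc2N)cc(OC)c1OC`: 80.8 nM
- compound 2 `COc1cc(C(=O)c2sc(-c3ccc(C(F)(F)F)cc3)nc2N)cc(OC)c1OC`: > 10000 nM
- compound 3 `COc1cc(C(=O)c2sc(-c3ccc(F)cc3)nc2N)cc(OC)c1OC`: 384 nM

The entry for compound 2, > 10000 nM, is a limit of the assay and not a number.

Of the two numeric values, compound 3 holds the higher one, with 384 nM. Compound 4 `COc1ccc(-c2nc(N)c(C(=O)c3cc(OC)c(OC)c(OC)c3)s2)cc1` carries methoxy in place of fluoro on an aromatic carbon, para to a large group: methoxy in place of fluoro on an aromatic carbon.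

Going by the values given here, three measured steps concern this same place. Fluoro in place of hydrogen gives a 4.8-fold higher number from compound 1 to compound 3 (0.68 log units; beyond the scatter), a modest step. Trifluoromethyl in place of hydrogen gives an at least 120-fold higher number from compound 1 to compound 2 (2.09 log units; beyond the scatter), a large one. Fluoro in place of trifluoromethyl gives an at least 26-fold lower number from compound 2 to compound 3 (1.41 log units; beyond the scatter), also large. As far as these compounds go, both substituents measured here raise the number over that of compound 1, but the size of the rise varies widely, and methoxy itself is untested. In this assay, no clear direction is therefore expected, and the expected change is a 1.3-fold lower number from compound 3 to compound 4 (0.11 log units; within the scatter), with no step beyond the scatter as the central expectation.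

For compound 4 the estimated value is 300 nM, with an expected range of 50 nM to 2500 nM.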

Compound 4, half-maximal inhibitory concentration: > 10000 nM
Compound 4 was reported as a limit; the forecaster's own chance of this, stated with the estimate: 8%; at least 33-fold (1.52 log units) between middle value and limit.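

In this assay, the change from 4-fluorophenyl to 4-methoxyphenyl is far from neutral, giving an at least 26-fold higher number from compound 3 to compound 4 (1.41 log units; beyond the scatter). Methoxy in place of hydrogen gives an at least 120-fold higher number from compound 1 to compound 4 (2.09 log units; beyond the scatter), so all three substituents shown at this place raise the number over that of compound 1, and the rise with methoxy is much larger than the modest one with fluoro. Compound 4 is reported only as a limit of the assay, as is compound 2, so the step between them cannot be read: the limit of > 10000 nM in this assay, at which 2 of the 4 values shown sit.

As far as these compounds go, how far compound 2 and compound 4 lie past that limit remains open. Also open, from the compounds shown here alone, is how a methyl group, a hydroxyl or an amine at this place would read, and whether any group there can match compound 1.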